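This account rests on a few compounds, and the source may have more. Where it says the series, first, only, none or still open, it means among the compounds named here.

Measured in a functional assay on HCT-116 cells (Homo sapiens) for inhibition, read by MTT assay, with a stated time of 48 h; on this read-out higher numbers stand for weaker inhibition and lower numbers for stronger inhibition:

- compound 1 `COc1ccc(CNc2cc(OC)c(OC)c(OC)c2)cc1Br`: 48100 nM
- compound 2 `COC(=O)c1cc(CNc2cc(OC)c(OC)c(OC)c2)ccc1OC`: 38100 nM
- compound 3 `COc1ccc(CNc2cc(OC)c(OC)c(OC)c2)cc1`: 18400 nM

Compound 3 stands lowest of the three numbers, and it is set apart from both neighbours by steps beyond the scatter: a 2.6-fold lower number from compound 1 to compound 3 (0.42 log units; beyond the scatter) and a 2.1-fold lower number from compound 2 to compound 3 (0.32 log units; beyond the scatter). Between the two substituted compounds the gap is small, a 1.3-fold lower number from compound 1 to compound 2 (0.10 log units; within the scatter), so bromo and methoxycarbonyl at this carbon are not told apart by this assay.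

Compound 4 `COc1ccc(CNc2cc(OC)c(OC)c(OC)c2)cc1[N+](=O)[O-]` is the next member. Its difference from compound 3 is nitro in place of hydrogen on an aromatic carbon. The two steps that bear on it are those in which a group at this same aromatic carbon was removed to give compound 3: in each case the substituted compound carried the higher number, by a modest margin, and the two substituents did not differ from one another. Within the data shown here, nothing among the measured compounds speaks for a nitro group behaving otherwise, so the expectation for compound 4 is a modest rise in the number against compound 3, of roughly the size seen with bromo and methoxycarbonyl, namely a 2.2-fold higher number from compound 3 to compound 4 (0.34 log units; beyond the scatter).

Compound 4 is therefore estimated at 40000 nM in this assay, with a range of 15000 nM to 100000 nM.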

Compound 4, half-maximal inhibitory concentration: 18200 nM
Compound 4: the middle estimate sits 2.2-fold (0.34 log units) above what was measured, and the stated range covers the measured number.
By their numbers in this assay, from the lowest: compounds 4 and 3 (each within the scatter of the next); then compounds 2 and 1 (each within the scatter of the next).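

In this assay the step of a 1.0-fold lower number from compound 3 to compound 4 (0.00 log units; within the scatter) shows that a substituent on this aromatic carbon, ortho to a methoxy group, need not go with a higher number: nitro and hydrogen are not told apart here. The link between substitution at this carbon and a higher number therefore holds only for bromo and methoxycarbonyl, and compound 4 goes against it, while the steps of a 2.1-fold lower number from compound 2 to compound 4 (0.32 log units; beyond the scatter) and a 2.6-fold lower number from compound 1 to compound 4 (0.42 log units; beyond the scatter) set nitro apart from both of those groups by modest margins beyond the scatter. No measurement at hand explains why nitro parts from the other two substituents.

On these data alone, whether an amine, a hydroxyl or a carboxylic acid on this carbon would fall with hydrogen and nitro or with bromo and methoxycarbonyl stays open. Also open is whether any group at this carbon can bring the number clearly under that of compound 3, since no substituent shown here does so.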